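This account rests on a few compounds, and the source may have more. Where it says the series, first, only, none or still open, it means among the compounds named here.

Compound 3 `CC1=C(/C=C/C(C)=C/C=C/C(C)=C\C(=O)Nc2ccccc2)C(C)(C)CCC1n1ccnc1` gives the lowest of the three numbers recorded so far in a functional assay on MDA-MB-468 cells (Homo sapiens) for inhibition, read by MTT assay (on this read-out lower numbers stand for stronger inhibition of growth and higher numbers for weaker inhibition of growth), at 2540 nM. Compound 1 `CC1=C(/C=C/C(C)=C/C=C/C(C)=C\C(=O)Nc2ccc(F)cc2)C(C)(C)CCC1n1ccnc1` gives 4570 nM in this assay, and the step of a 1.8-fold lower number from compound 1 to compound 3 (0.26 log units; within the scatter) lies within the scatter. Within the data shown here, compound 2 `CC1=C(/C=C/C(C)=C/C=C/C(C)=C\C(=O)NCc2ccc(O)cc2)C(C)(C)CC=C1c1cncnc1` gives 19100 nM in this assay, a number beyond the scatter from compound 3, but no single step connects it to either of the others, since its core differs as well. Compound 4 `CC1=C(/C=C/C(C)=C/C=C/C(C)=C\C(=O)NCc2ccccc2)C(C)(C)CCC1n1ccnc1` is to be measured in this assay; it differs from compound 3 by benzyl in place of phenyl on an amide-type nitrogen. Among the measured compounds shown here, no measured step bears directly on this change. Compound 2 does carry a benzyl-type amide, yet it differs from compound 3 in more than one place, so its higher number cannot be assigned to the amide alone. With nothing to anchor the change, no step beyond the scatter is expected a 1.6-fold higher number from compound 3 to compound 4 (0.20 log units; within the scatter), though the range is kept wide. Compound 4 is therefore estimated at 4000 nM in this assay, between 1300 nM and 12000 nM.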

Compound 4, concentration for 50% growth inhibition: 7240 nM
Estimate against measurement, compound 4: 1.8-fold (0.26 log units) below; measured number inside the range.
By their numbers in this assay, from the lowest: compounds 3, 1 and 4 (each within the scatter of the next, the first and the last beyond it); then compound 2.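

Benzyl in place of phenyl on an amide-type nitrogen, a change no earlier pair covered, gives a 2.9-fold higher number from compound 3 to compound 4 (0.45 log units; beyond the scatter) in this assay, so with the core held constant this position responds to the change. The picture is less sharp against the 4-fluorophenyl amide: a 1.6-fold higher number from compound 1 to compound 4 (0.20 log units; within the scatter) shows that benzyl cannot be told apart from 4-fluorophenyl here, and only the unsubstituted phenyl stands clearly apart from benzyl. No measurement at hand accounts for the step.

The compounds shown leave open whether a longer chain such as phenethyl on this nitrogen would carry the number further the same way, and whether an amine or a carboxylic acid on the benzyl ring would change it on this core. Compound 2 cannot settle this, since its core differs as well.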